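The source may report more compounds than this note shows. Statements on the series, on what has been measured and on what is new or still open speak of the compounds shown alone.

Compound 1 (`Fc1ccc(-c2cn(CC3=C(Cl)c4ccc(-c5cccs5)nc4CC3)nn2)cc1`) gives 100 ug/mL in an ADME assay on MDCK cells (Canis lupus familiaris) for cytotoxicity, read by MTT assay, with a stated time of 48 h; on this read-out higher numbers stand for lower toxicity in this test and lower numbers for higher toxicity in this test
Compound 2 (`FC(F)(F)Oc1ccc(-c2cn(CC3=C(Cl)c4ccc(-c5cccs5)nc4CC3)nn2)cc1`) gives > 300 ug/mL in this assay (a limit)

Compound 2 stands at the limit of > 300 ug/mL in this assay, at which 1 of the 2 values shown sits, and so has only a limit, not a number. Compound 3 (`FC(F)(F)c1ccccc1-c1cn(CC2=C(Cl)c3ccc(-c4cccs4)nc3CC2)nn1`) has not yet been measured. It differs from compound 2 on an aromatic carbon of a five-membered aromatic ring with 3 nitrogen, where 2-(trifluoromethyl)phenyl replaces 4-(trifluoromethoxy)phenyl (2-(trifluoromethyl)phenyl in place of 4-(trifluoromethoxy)phenyl on an aromatic carbon). Among the measured compounds shown here, the only measured step is an at least 3.0-fold higher number from compound 1 to compound 2 (0.47 log units; beyond the scatter) and it also exchanges a group on that phenyl ring. However, 2-(trifluoromethyl)phenyl occurs in neither measured compound, so this step bears on the change only loosely. It does show that the group on this ring can move the reading beyond the scatter. For the measured compounds named here, compound 1 at 100 ug/mL is the only true number. A somewhat lower number than the limit of compound 2 is expected in this assay, possibly not beyond the scatter. The estimated change is an at least 1.5-fold lower number from compound 2 to compound 3 (0.17 log units; that floor lies within the scatter) and it remains uncertain. Compound 3 is estimated at 200 ug/mL with an expected range from 80 ug/mL to 450 ug/mL in this assay.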

Compound 3, half-maximal cytotoxic concentration: > 300 ug/mL
Compound 3 ended at the assay's limit; the forecaster's own chance of this, stated with the estimate: 35%; middle value at least 1.5-fold (0.17 log units) away from the limit.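

In this assay, 2-(trifluoromethyl)phenyl in place of 4-fluorophenyl gives an at least 3.0-fold higher number from compound 1 to compound 3 (0.47 log units; beyond the scatter), so on this aromatic carbon of the five-membered aromatic ring with 3 nitrogen, a second group now stands clear of 4-fluorophenyl, as 4-(trifluoromethoxy)phenyl already did. The step holds for an entering group with 0 hydrogen-bond acceptors as well as for 4-(trifluoromethoxy)phenyl with 1, so among these compounds the higher number does not require that acceptor. The step between compound 2 and compound 3 cannot be read, because both sit at the same limit: the limit of > 300 ug/mL in this assay, at which 2 of the 3 values shown sit.

Going by these compounds, how far compound 2 and compound 3 each lie past that limit stays open, and with it any order between 2-(trifluoromethyl)phenyl and 4-(trifluoromethoxy)phenyl. Also open, on these data alone, is whether an amine or a carboxylic acid on the phenyl ring would keep the reading at the limit or bring it back toward the true number of compound 1.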